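A few compounds are considered here, and "the series" means these few. Any claim that something is new, unique, unknown or untested is made for them only; others in the source may bear on it.

Working notes on the series. The shared core of compound 1 `CCC(CC)Nc1cc(C)nc2c(-c3cnc(N(C)C)cc3C)c(C)nn12` gives 9.4 nM in an assay on CHO cells for binding affinity to corticotropin-releasing factor receptor 1 (Homo sapiens); a higher number here means a weaker inhibitor, a lower number a stronger inhibitor. Compound 2 `CCCC(CCC)Nc1cc(C)nc2c(-c3cnc(N(C)C)cc3C)c(C)nn12` gives 4.8 nM, compound 3 `CCCCN(CC)c1cc(C)nc2c(-c3cnc(N(C)C)cc3C)c(C)nn12` gives 2.6 nM. Compound 3 sits at the low end of the three numbers: the step of a 1.8-fold lower number from compound 2 to compound 3 (0.27 log units; within the scatter) lies within the scatter, whereas a 3.6-fold lower number from compound 1 to compound 3 (0.56 log units; beyond the scatter) lies beyond it, a modest move. Compound 4 `CCCN(CC1CC1)c1cc(C)nc2c(-c3cnc(N(C)C)cc3C)c(C)nn12` differs from compound 3 by (cyclopropylmethyl)(propyl)amino in place of butyl(ethyl)amino on an aromatic carbon. The steps of a 3.6-fold lower number from compound 1 to compound 3 (0.56 log units; beyond the scatter) and a 1.8-fold lower number from compound 2 to compound 3 (0.27 log units; within the scatter) both altered the same amino substituent and moved the number little or modestly, so for compound 4 a step no larger than the scatter is expected, a 1.2-fold higher number from compound 3 to compound 4 (0.06 log units; within the scatter). Compound 4 is estimated at 3 nM, with a range from 1.2 nM to 8 nM.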

Compound 4, inhibition constant: 2.6 nM
Estimate against measurement, compound 4: 1.2-fold (0.06 log units) above; low and high end bracket the measured number.
By their numbers in this assay, from the lowest: compounds 3, 4, 2 and 1 (each within the scatter of the next, the first and the last beyond it).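

In this assay the amino substituent accepts a three-membered ring of carbon only: (cyclopropylmethyl)(propyl)amino in place of butyl(ethyl)amino gives no change at the digits printed from compound 3 to compound 4 (within the scatter) and so matches the earlier best value. Against the branched groups, the new substituent gives a 1.8-fold lower number from compound 2 to compound 4 (0.27 log units; within the scatter) and a 3.6-fold lower number from compound 1 to compound 4 (0.56 log units; beyond the scatter), with only the second step beyond the scatter. Nothing measured here offers a reason for this result.

Open, on these data alone, is whether a 2-methoxyethyl chain or a morpholine on the same aromatic carbon would keep the number in this assay at this level.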